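Aryl swap in a weakly cytotoxic series

The source may hold more compounds than are shown below. What is called first, only, known or untested is meant among the compounds shown, and "the series" means these compounds.

The series is built on one shared core, shown for compound 1 `C=CCn1c(=O)/c(=C\c2ccc(Cl)c(Cl)c2)[nH]c(=O)/c1=C\c1ccccc1`, compound 2 `C=CCn1c(=O)/c(=C\c2cccc(F)c2)[nH]c(=O)/c1=C\c1ccccc1OC` and compound 3 `C=CCn1c(=O)/c(=C\c2ccc(Cl)c(Cl)c2)[nH]c(=O)/c1=C\c1ccccc1OC`. In a functional assay on NCI-H1975 cells (Homo sapiens) for cytotoxicity, read by CCK-8 assay, with a stated time of 72 h (on this read-out higher numbers stand for weaker inhibition and lower numbers for stronger inhibition), compound 1 gives "not active" (no number reported), reported without a number. In this assay compound 3 likewise gives "not active" (no number reported), again without a number. Compound 2 is the only member with a reported figure: in this assay compound 2 gives 25600 nM, a weak result, and on the numbers shown it stands alone, with nothing to order it against.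

Compound 4 `C=CCn1c(=O)/c(=C\c2cc(Br)ccc2F)[nH]c(=O)/c1=C\c1ccccc1OC` has not been measured. It differs from compound 2 in one place: 5-bromo-2-fluorophenyl in place of 3-fluorophenyl on a double-bonded chain carbon bound to an aromatic carbon. Among the compounds with values here, no measured pair of this kind is available, so the size of the step cannot be read from the data. Given that compound 2 sits at 25600 nM and the two other members report no number, the step from compound 2 to compound 4 is expected to be small or toward weaker inhibition, around a 1.4-fold higher number from compound 2 to compound 4 (0.14 log units; within the scatter). Compound 4 is therefore estimated at 35000 nM in this assay, within a range of 10000 nM to 120000 nM, with a real chance that only an inactive result is reported.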

Compound 4, half-maximal inhibitory concentration: "not active" (no number reported)
The entry for compound 4 holds no number; the estimate stays without a comparison.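

In this assay, within the data shown here, compound 4 gives "not active" (no number reported), so no step from compound 2 to compound 4 can be read. The compounds shown leave open whether any aryl swap on compound 2 gives a stronger figure. No supporting data bear on this result.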